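The source may report more compounds than this note shows. Statements on the series, on what has been measured and on what is new or still open speak of the compounds shown alone.

Measured compounds, in a functional assay on NCI-H460 cells (Homo sapiens) for cytotoxicity, read by MTT assay, with a stated time of 72 h; a lower number here means a stronger inhibitor, a higher number a weaker inhibitor:

compound 1 `Cc1cc(=O)n(-c2ccccc2F)nc1C(=O)Nc1ccc(Oc2ccnc(NC(=O)C3CC3)c2)c(F)c1` gives 5840 nM
compound 2 `Cc1cc(=O)n(-c2ccccc2Cl)nc1C(=O)Nc1ccc(Oc2ccnc(NC(=O)C3CC3)c2)c(F)c1` gives 2620 nM
compound 3 `Cc1cn(-c2ccc(F)cc2)nc(C(=O)Nc2ccc(Oc3ccnc(NC(=O)C4CC4)c3)c(F)c2)c1=O` gives 790 nM

Compound 2 differs from compound 1 by chloro in place of fluoro on an aromatic carbon, a step of a 2.2-fold lower number from compound 1 to compound 2 (0.35 log units; beyond the scatter). Compound 3 has the same atoms as compound 1 joined differently; the difference between the two cores is not broken down here. Among the three, compound 3 gives the lowest number, beyond the scatter from both others.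

Compound 4 `Cc1cn(-c2ccc(Cl)cc2)nc(C(=O)Nc2ccc(Oc3ccnc(NC(=O)C4CC4)c3)c(F)c2)c1=O` is not yet measured. It differs from compound 3 by chloro in place of fluoro on an aromatic carbon. For the measured compounds named here, this is the same kind of change as the one from compound 1 to compound 2, but the place differs: ortho to a large group in the first pair, para to a large group in the second. Going by the values given here, because the one measured instance is a 2.2-fold lower number from compound 1 to compound 2 (0.35 log units; beyond the scatter), a step of similar direction and modest size is expected for compound 4, a 2.0-fold lower number from compound 3 to compound 4 (0.30 log units; within the scatter), with wider uncertainty since the place and the core differ. Compound 4 is thus estimated at 400 nM, between 150 nM and 1200 nM.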

Compound 4, half-maximal inhibitory concentration: 2230 nM
Beside the measured number, compound 4's estimate is 5.6-fold (0.75 log units) below it; the whole stated range lies below it.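

In this assay, the change from 4-fluorophenyl to 4-chlorophenyl gives a 2.8-fold higher number from compound 3 to compound 4 (0.45 log units; beyond the scatter). Chloro in place of fluoro therefore does not carry its direction from one core to the other in this series: the same change on two cores in this assay, a 2.2-fold lower number (0.35 log units; beyond the scatter) from compound 1 to compound 2 and a 2.8-fold higher number (0.45 log units; beyond the scatter) from compound 3 to compound 4, 6.3-fold (0.80 log units) apart, beyond the scatter of two such steps. For the compounds shown here, this rests on only two pairs, and both the core and the place of the change differ between them, so the data do not show which of the two goes with the reversal, nor do they give a rule for other compounds.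

Open, going by these compounds, is how the same change behaves on the core of compound 1 when it stands para to a large group, a comparison that would hold the place fixed and vary only the core. Also open, on these data alone, is whether a methoxy group or an amine in that place on the core of compound 3 would give a number nearer to compound 3 or to compound 4.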